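Crown Ether Esters Against a Lung Cancer Cell Line

A few compounds are considered here, and "the series" means these few. Any claim that something is new, unique, unknown or untested is made for them only; others in the source may bear on it.

Of the compounds shown here, three have been measured in a functional assay on SW1573 cells (Homo sapiens) for inhibition, read by sulforhodamine B assay, with a stated time of 48 h; a lower number here means a stronger inhibitor of growth, a higher number a weaker inhibitor of growth. Compound 1 `O=C(CCCCCc1ccccc1)OCC1COCCOCCOCCOCCOCCO1` gives 78000 nM. Compound 2 `O=C(CCCCC1CCCCC1)OCC1COCCOCCOCCOCCO1` gives > 100000 nM, a limit of the assay rather than a number. Compound 3 `CC(C)=CC1C(C(=O)OCC2COCCOCCOCCOCCOCCO2)C1(C)C` gives 54000 nM.

Of the two numbers, compound 1 holds the higher, but the step of a 1.4-fold lower number from compound 1 to compound 3 (0.16 log units; within the scatter) lies within the scatter, so the two cannot be told apart. Compound 2 sits at the limit of > 100000 nM in this assay, at which 1 of the 3 values shown sits.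

Compound 4 `CC/C=C/CC(=O)OCC1COCCOCCOCCOCCOCCO1` differs from compound 1 by but-1-en-1-yl in place of 4-phenylbutyl on a saturated chain carbon bound to a carbonyl carbon. Among the measured compounds shown here, the one measured step, a 1.4-fold lower number from compound 1 to compound 3 (0.16 log units; within the scatter), also exchanged the acyl part and moved nothing beyond the scatter, so no bearing step points clearly in either direction. For compound 4 the expected step is a 1.2-fold higher number from compound 1 to compound 4 (0.09 log units; within the scatter). The estimate for compound 4 is 95000 nM, with a range from 45000 nM to 200000 nM.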

Compound 4, concentration for 50% growth inhibition: > 100000 nM
Compound 4: a limit, no number; the forecaster's own chance of this, stated with the estimate: 45%; at least 1.0-fold (0.02 log units) between middle value and limit.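

Replacing 4-phenylbutyl with but-1-en-1-yl on a saturated chain carbon bound to a carbonyl carbon removes the aromatic ring, and compound 4 gives only a limit of the assay, not a number: the limit of > 100000 nM in this assay, at which 2 of the 4 values shown sit. The readings an at least 1.2-fold higher number from compound 1 to compound 4 (0.10 log units; that floor lies within the scatter) and an at least 1.8-fold higher number from compound 3 to compound 4 (0.26 log units; that floor lies within the scatter) are both floors. This acyl part therefore cannot yet be separated from the other two, although the limit leaves room for a wider gap. Going by these compounds, whether an amine, a carboxylic acid or a longer chain at this position would shift growth inhibition beyond the scatter remains open.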